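The source may report more compounds than this note shows. Statements on the series, on what has been measured and on what is new or still open speak of the compounds shown alone.

Of the compounds shown here, three have been measured in a toxicity assay on mitochondria from liver (Rattus norvegicus) for inhibition, in the presence of a further agent that is not named here; a lower number here means a stronger inhibitor, a higher number a weaker inhibitor. Compound 1 `Cc1c(C)n(C(=O)c2ccc(O)c(C#N)c2)c2ccccc12` gives 3600 nM, compound 2 `CC(C)(C)c1cc(C(=O)N2CCc3ccccc32)cc(C#N)c1O` gives 6600 nM and compound 3 `N#Cc1cc(C(=O)N2CCc3ccccc32)cc(C2CC2)c1O` gives 24000 nM. Compound 2 cannot be told apart from compound 1 within the usual scatter of repeated measurements, while compound 3 stands clearly apart from compound 2 as the weaker inhibitor.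

Compound 4 `N#Cc1cc(C(=O)N2CCc3ccccc32)cc(Cl)c1O` has not yet been measured. It differs from compound 2 by one change: chloro in place of tert-butyl on an aromatic carbon. Chloro takes the place of tert-butyl on an aromatic carbon, ortho to a hydroxy group and meta to a cyano group.

For the measured compounds named here, only one measured step bears on this change. With cyclopropyl in place of the same tert-butyl, the data show a 3.6-fold higher number from compound 2 to compound 3 (0.56 log units; beyond the scatter). Going by the values given here, no measured compound carries chloro, so this modest step is the only guide, and a loose one. Going by compound 3 at 24000 nM, a step of similar size in the same direction, toward a weaker inhibitor, is expected in this assay. The expected step is a 2.7-fold higher number from compound 2 to compound 4 (0.44 log units; beyond the scatter). Compound 4 is expected at 18000 nM, with an estimated range from 6000 nM to 50000 nM.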

Compound 4, half-maximal inhibitory concentration: 31000 nM
Estimate against measurement, compound 4: 1.7-fold (0.24 log units) below; measured number inside the range.
By their numbers in this assay, from the lowest: compounds 1 and 2 (each within the scatter of the next); then compounds 3 and 4 (each within the scatter of the next).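

In this assay, a second replacement of the tert-butyl on this aromatic carbon, ortho to a hydroxy group and meta to a cyano group, again gives a weaker inhibitor, with a 4.7-fold higher number from compound 2 to compound 4 (0.67 log units; beyond the scatter) alongside the earlier 3.6-fold higher number from compound 2 to compound 3 (0.56 log units; beyond the scatter) for cyclopropyl, so the earlier step no longer stands alone and, of the three groups seen at this place, tert-butyl gives the stronger inhibitor, with no compound among these three going against it. Chloro and cyclopropyl cannot be told apart here, since a 1.3-fold higher number from compound 3 to compound 4 (0.11 log units; within the scatter) stays within the usual scatter, even though chloro brings 1 heavy atom where tert-butyl has 4 carbon. No measurement of any property of these groups is at hand to account for these steps.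

From the compounds shown here alone, it remains open how a methoxy group, an amine, a carboxylic acid or a longer chain would read on this carbon, and whether bromo or fluoro would fall with chloro. For the compounds shown here, it is also open whether the step from tert-butyl to chloro would keep its size with the amide part of compound 1 in place of the one shared by compound 2 and compound 4.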